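Taking the chloro off compound 2

This account rests on a few compounds, and the source may have more. Where it says the series, first, only, none or still open, it means among the compounds named here.

Compound 2 `Cc1nnc(SCC(=O)c2ccc(Cl)cc2)n1N1C(=O)c2ccccc2C1=O` is measured in a functional assay on A549 cells (Homo sapiens) for cytotoxicity, read by MTT assay, with a stated time of 48 h; on this read-out higher numbers stand for weaker inhibition and lower numbers for stronger inhibition. In this assay compound 2 gives only the limit > 200000 nM, not a number. Compound 1 `Cc1nnc(SCc2ccccc2)n1N1C(=O)c2ccccc2C1=O` likewise reaches only the limit > 200000 nM in this assay. The step that the two limits leave unreadable from compound 1 to compound 2 is not readable, as both values sit at the limit of > 200000 nM in this assay, at which 2 of the 2 values shown sit. Compound 3 `Cc1nnc(SCC(=O)c2ccccc2)n1N1C(=O)c2ccccc2C1=O` differs from compound 2 by hydrogen in place of chloro on an aromatic carbon, the same change read one bond further out being 4-chlorophenyl to phenyl. Within the data shown here, no measured step bears on this change directly; the only step, from compound 1 to compound 2, is unreadable, and both values shown are limits. Compound 3 is therefore expected to remain at the limit, with an estimated step that the limit leaves unreadable from compound 2 to compound 3 that cannot be read beyond the scatter. Compound 3 is estimated at 300000 nM, in the range 120000 nM to 1000000 nM, most likely reported as a limit again.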

Compound 3, half-maximal inhibitory concentration: > 200000 nM
Compound 3: no number, only a limit; the forecaster's own chance of this, stated with the estimate: 85%; the middle value lies beyond the limit too.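

No new step can be read among compound 1, compound 2 and compound 3, as all three sit at one limit of the assay: the limit of > 200000 nM in this assay, at which 3 of the 3 values shown sit.
The compounds shown leave open whether any change on the shared core would bring a readable number in this assay.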